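The source may report more compounds than this note shows. Statements on the series, on what has been measured and on what is new or still open speak of the compounds shown alone.

Three members of the series share one core and differ only in the group on the carbonyl carbon of the amide. Compound 1 `CSCC(=O)N1CCN(c2nc(=O)c3cc(C(F)(F)F)cc([N+](=O)[O-])c3s2)CC1` gives 15.2 ug/mL in a physicochemical assay for solubility, read by HPLC; on this read-out lower numbers stand for lower solubility and higher numbers for higher solubility. Compound 2 `O=C(C1CC1)N1CCN(c2nc(=O)c3cc(C(F)(F)F)cc([N+](=O)[O-])c3s2)CC1` gives 52.9 ug/mL in this assay, and compound 3 `O=C(C1CCCC1)N1CCN(c2nc(=O)c3cc(C(F)(F)F)cc([N+](=O)[O-])c3s2)CC1` gives 5.34 ug/mL. Compound 3 holds the lowest number of the three: a 2.8-fold lower number from compound 1 to compound 3 (0.45 log units; beyond the scatter) and a 9.9-fold lower number from compound 2 to compound 3 (1.00 log units; beyond the scatter), both beyond the scatter, while a 3.5-fold higher number from compound 1 to compound 2 (0.54 log units; beyond the scatter).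

The next compound, compound 4 `O=C(c1ccc(F)cc1)N1CCN(c2nc(=O)c3cc(C(F)(F)F)cc([N+](=O)[O-])c3s2)CC1`, differs from compound 3 in that (4-fluorophenyl in place of cyclopentyl on a carbonyl carbon). All three measured steps concern the group on this same carbonyl carbon, so each bears on the change, yet none of them places an aromatic ring there; the nearest reference is the swap between compound 2 and compound 3, where the non-aromatic ring of five carbons left compound 3 at the bottom of the three. With no aromatic comparator in the series, the expectation is that the number for compound 4 stays close to that of compound 3, and the expected step is a 1.1-fold higher number from compound 3 to compound 4 (0.05 log units; within the scatter), within the usual scatter. Compound 4 is therefore estimated at 6 ug/mL, with a likely range from 2.5 ug/mL to 15 ug/mL.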

Compound 4, solubility: 1.69 ug/mL
Compound 4: middle estimate off by 3.6-fold (0.55 log units), on the high side, and the stated range ends above it.
By their numbers in this assay, from the lowest: compound 4; then compound 3; then compound 1; then compound 2.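

In this assay, within the data shown here, 4-fluorophenyl on the carbonyl carbon gives the lowest number of the four compounds, with a 3.2-fold lower number from compound 3 to compound 4 (0.50 log units; beyond the scatter) and a 9.0-fold lower number from compound 1 to compound 4 (0.95 log units; beyond the scatter) and also a 31-fold lower number from compound 2 to compound 4 (1.50 log units; beyond the scatter), the only large step in the set. The swap thus widens the spread at this one position beyond what the three non-aromatic groups showed, and the three ring groups now fall in the order cyclopropyl, cyclopentyl, 4-fluorophenyl, with the open-chain (methylsulfanyl)methyl of compound 1 sitting inside that order and not at either end of it. Nothing measured on these compounds accounts for the drop, so the step stands as an observation without an explanation.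

Compound 4 changes ring type and adds fluorine in one move, and a plain phenyl on the same carbonyl carbon would be needed to tell the aromatic ring apart from the fluorine. From the compounds shown here alone, whether an amine or a carboxylic acid carried on this carbonyl carbon would move the number past that of compound 2 remains open.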